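This account rests on a few compounds, and the source may have more. Where it says the series, first, only, none or still open, it means among the compounds named here.

Measured so far in a functional assay on NCI-H1975 cells (Homo sapiens) for antiproliferative activity, read by MTT assay, with a stated time of 72 h; a higher number here means a weaker inhibitor, a lower number a stronger inhibitor:
compound 1, `C#Cc1cccc(Nc2ncnc3cc(OC)c(OCCCCC(=O)Nc4ccc(S(N)(=O)=O)cc4)cc23)c1`, gives 18800 nM.
compound 2, `COc1cc2ncnc(Nc3cccc(Cl)c3)c2cc1OCCCCC(=O)Nc1ccc(S(N)(=O)=O)cc1`, gives 33200 nM.
compound 3, `COc1cc2ncnc(Nc3cccc(F)c3)c2cc1OCCCCC(=O)Nc1ccc(S(N)(=O)=O)cc1`, gives > 40000 nM, which is a limit of the assay and not a number.

Compound 3 therefore sits at the limit of > 40000 nM in this assay, at which 1 of the 3 values shown sits; its standing among the three is known only to the extent that the step from compound 1 is an at least 2.1-fold higher number from compound 1 to compound 3 (0.32 log units; beyond the scatter), while the step from compound 2 is an at least 1.2-fold higher number from compound 2 to compound 3 (0.08 log units; that floor lies within the scatter).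

Compound 4, `COc1cc2ncnc(Nc3ccc(Br)cc3)c2cc1OCCCCC(=O)Nc1ccc(S(N)(=O)=O)cc1`, is still to be measured. It differs from compound 3 by 4-bromophenyl in place of 3-fluorophenyl on a nitrogen on an aromatic ring. Of the measured steps, the closest in kind are those that vary the substituent on this same aryl ring: a 1.8-fold higher number from compound 1 to compound 2 (0.25 log units; within the scatter) and an at least 1.2-fold higher number from compound 2 to compound 3 (0.08 log units; that floor lies within the scatter), both small, and an at least 2.1-fold higher number from compound 1 to compound 3 (0.32 log units; beyond the scatter), which is at least modest. For the measured compounds named here, no measured pair places a substituent at the position used in compound 4, so the change in position is not covered by the data.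

The expectation for compound 4 is a step of an at least 1.1-fold lower number from compound 3 to compound 4 (0.05 log units; that floor lies within the scatter), that is, a number staying close to compound 2 and compound 3, with a real chance that this assay again reports only a limit. Compound 4 is estimated at 35000 nM, with a range from 15000 nM to 80000 nM.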

Compound 4, half-maximal inhibitory concentration: 23300 nM
Compound 4: middle estimate off by 1.5-fold (0.18 log units), on the high side, within the range that was stated.
By their numbers in this assay, from the lowest: compounds 1, 4 and 2 (each within the scatter of the next). At a limit, above all of these: compound 3.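

In this assay, the 4-bromophenyl group gives the first readout for a substituent at this position on the aryl ring, and it leaves compound 4 within the scatter of both compounds that carry a measured 3-substituted ring (a 1.4-fold lower number from compound 2 to compound 4 (0.15 log units; within the scatter); a 1.2-fold higher number from compound 1 to compound 4 (0.09 log units; within the scatter)). Within these pairs, the change of both substituent and position on the group attached to the nitrogen therefore brings no change that can be separated from the scatter, so this position accepts a bromine at least as far as this single example shows. Against compound 3 only a floor can be read (an at least 1.7-fold lower number from compound 3 to compound 4 (0.23 log units; that floor lies within the scatter)), and that floor does not establish a real gain of 4-bromophenyl over 3-fluorophenyl, since the value of compound 3 is a limit of the assay and not a number: the limit of > 40000 nM in this assay, at which 1 of the 4 values shown sits.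

The compounds shown do not separate the effect of the halogen from that of its position, which a pairing of 3-bromophenyl with 4-bromophenyl would address. They also leave open whether a carboxylic acid in place of the sulfonamide, or a longer chain on the oxygen of the core, would move the numbers in this assay beyond the scatter.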